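The compounds below may be only part of what the source reports. "The series", "measured", "known", "first", "only" and "open" are said of these compounds alone.

Of the compounds shown here, three sharing one core have been measured in an ADME assay on HepG2 2.2.15 cells (Homo sapiens) for cytotoxicity, read by MTT assay, with stated times of 48 h and 9 days; on this read-out lower numbers stand for higher toxicity in this test and higher numbers for lower toxicity in this test. Compound 1 `COc1ccc2c(=O)c(/C=C/C(=O)Nc3ccc(C)cc3)coc2c1` gives 979000 nM. Compound 2 `COc1ccc2c(=O)c(/C=C/C(=O)NCc3cccc(F)c3)coc2c1` gives 475000 nM. Compound 3 `COc1ccc2c(=O)c(/C=C/C(=O)NCc3ccc(C)cc3)coc2c1` gives 257000 nM, the lowest of the three numbers; its gap to compound 2 lies within the scatter, so no order between those two can be claimed, while the step of a 3.8-fold lower number from compound 1 to compound 3 (0.58 log units; beyond the scatter) stands beyond it.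

The next compound, compound 4 `COc1ccc(NC(=O)/C=C/c2coc3cc(OC)ccc3c2=O)cc1`, is not yet measured. It differs from compound 3 in one place: 4-methoxyphenyl in place of 4-methylbenzyl on an amide-type nitrogen. Among the measured compounds shown here, two measured steps bear on this. The step of a 3.8-fold lower number from compound 1 to compound 3 (0.58 log units; beyond the scatter) shows what replacing a phenyl-type group with a benzyl-type group on the amide nitrogen did, and the step of a 2.1-fold lower number from compound 1 to compound 2 (0.31 log units; beyond the scatter) points the same way. Compound 4 reverses that kind of change, returning to an aryl group on the amide nitrogen, with a methoxy group where compound 1 carried a methyl; how that swap alone behaves is not shown by any measured pair here.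

On this basis the number for compound 4 is expected to rise, by an estimated step of a 3.1-fold higher number from compound 3 to compound 4 (0.49 log units; beyond the scatter). The estimate for compound 4 in this assay is 800000 nM, with a range from 350000 nM to 1800000 nM.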

Compound 4, half-maximal cytotoxic concentration: 718000 nM
Estimate against measurement, compound 4: 1.1-fold (0.05 log units) above, and the stated range covers the measured number.
By their numbers in this assay, from the lowest: compounds 3, 2, 4 and 1 (each within the scatter of the next, the first and the last beyond it).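

In this assay, methoxy in place of methyl on an aromatic carbon gives a 1.4-fold lower number from compound 1 to compound 4 (0.13 log units; within the scatter), which lies within the scatter, so at this site the assay does not tell the two groups apart. Among the compounds shown here, this is the first measured pair that keeps a phenyl-type group on the amide-type nitrogen and changes only its substituent. The contrast with benzyl-type groups is only partly upheld: a 2.8-fold higher number from compound 3 to compound 4 (0.45 log units; beyond the scatter) lies beyond the scatter, pointing the same way as the earlier step from compound 1 to compound 3, whereas a 1.5-fold higher number from compound 2 to compound 4 (0.18 log units; within the scatter) lies within it, so compound 2 goes against any clean split between the two kinds of group, and nothing available explains these differences.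

The compounds shown leave open whether 4-methoxybenzyl on the same nitrogen would repeat the step seen between the two 4-methyl compounds, compound 1 and compound 3. They also leave open how an amine or a carboxylic acid on the ring, or a longer chain between the amide nitrogen and the ring, would read in this assay.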